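The compounds below may be only part of what the source reports. "The series", "measured", "known", "first", "only" and "open" are said of these compounds alone.

Of the compounds shown here, three sharing one core have been measured in a functional assay (Homo sapiens) for inhibition; on this read-out lower numbers stand for stronger inhibition and higher numbers for weaker inhibition. Compound 1 `CS(=O)(=O)c1ccc(CSc2nc(-c3ccc(F)cc3)c(-c3ccncc3)[nH]2)cc1` gives 330 nM, compound 2 `CSc1ccc(CSc2nc(-c3ccc(Br)cc3)c(-c3ccncc3)[nH]2)cc1` gives 2400 nM, and compound 3 `C[S+]([O-])c1ccc(CSc2nc(-c3ccc(Br)cc3)c(-c3ccncc3)[nH]2)cc1` gives 820 nM, so compound 3 sits in the middle of the three numbers.

The next compound, compound 4 `CS(=O)(=O)c1ccc(CSc2nc(-c3ccc(Br)cc3)c(-c3ccncc3)[nH]2)cc1`, alters one group of compound 3: a group of 4 heavy atoms (1 carbon, 2 oxygen, 1 sulfur; no ring) in place of a group of 3 heavy atoms (1 carbon, 1 oxygen, 1 sulfur; no ring), on an aromatic carbon. The entering methylsulfonyl group stands on an aromatic carbon, para to a large group.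

The closest measured change at this place is a 2.9-fold lower number from compound 2 to compound 3 (0.47 log units; beyond the scatter), a modest step toward stronger inhibition. Within the data shown here, compound 1, the only measured compound that already carries methylsulfonyl, gives 330 nM. This is thin evidence, so a step in the same direction is expected in this assay, though smaller and possibly no larger than the usual scatter. The expected change is a 2.0-fold lower number from compound 3 to compound 4 (0.29 log units; within the scatter). For compound 4 the estimated value is 420 nM, with an expected range of 180 nM to 950 nM.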

Compound 4, half-maximal inhibitory concentration: 640 nM
Compound 4: middle estimate off by 1.5-fold (0.18 log units), on the low side; the range from low to high includes it.
By their numbers in this assay, from the lowest: compounds 1, 4 and 3 (each within the scatter of the next, the first and the last beyond it); then compound 2.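

In this assay, placing methylsulfonyl on this aromatic carbon gives a 1.3-fold lower number from compound 3 to compound 4 (0.11 log units; within the scatter), so this change cannot be told apart from the usual scatter. Set against methylsulfanyl, the same group gives a 3.8-fold lower number from compound 2 to compound 4 (0.57 log units; beyond the scatter), which lies beyond the scatter, so the stronger inhibition first seen with compound 3 is kept at this position but not clearly extended. Among these compounds, compound 4 also forms the first matched pair for the halogen on the other aromatic ring: with methylsulfonyl held constant, bromo in place of fluoro gives a 1.9-fold higher number from compound 1 to compound 4 (0.29 log units; within the scatter), again within the scatter.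

As far as these compounds go, whether an amine or a carboxylic acid on this aromatic carbon would move the number further remains open. No measured evidence here explains why methylsulfanyl stands apart from the other two groups.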